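The compounds below may be only part of what the source reports. "The series", "measured", "known", "first", "only" and "open" are said of these compounds alone.

Compound 1 `C[C@H]1[C@H](NCc2cc(C3CC3)cs2)C[C@H]2C[C@@H]1C2(C)C` in an ADME assay on MDCK cells (Canis lupus familiaris) for cytotoxicity, read by microscopy, with a stated time of 48 h (a lower number here means that less compound is tolerated, a higher number that more compound is tolerated), gives 25000 nM.
Compound 2 `CCc1csc(CN[C@@H]2C[C@H]3C[C@@H]([C@H]2C)C3(C)C)c1` in this assay gives 25000 nM.
For compound 3 `C[C@H]1[C@H](NCc2cncnc2)C[C@H]2C[C@@H]1C2(C)C` the this assay reports only a limit, > 100000 nM.

Compound 3 thus sits at the limit of > 100000 nM in this assay, at which 1 of the 3 values shown sits, the edge of what the assay can report, so its true value is not a number. Compound 4 `Cc1csc(CN[C@@H]2C[C@H]3C[C@@H]([C@H]2C)C3(C)C)c1` differs from it by one change: 4-methylthiophen-2-yl in place of pyrimidin-5-yl on a saturated chain carbon bound to an amine nitrogen. Going by the values given here, no measured step covers this swap of one aromatic ring for another. Among the compounds with values here, the only measured step, no change at the digits printed from compound 1 to compound 2 (within the scatter), varies a small group on the same thiophene ring that compound 4 carries, and it lies within the scatter. Compounds 1 and 2 both carry that thiophene ring and both give the same value. Compound 4 is therefore expected to come off the limit and land near them, a step of an at least 4.0-fold lower number from compound 3 to compound 4 (0.60 log units; beyond the scatter). The estimate for compound 4 is 25000 nM, with a range from 10000 nM to 100000 nM.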

Compound 4, minimum cytotoxic concentration: 12500 nM
Estimate against measurement, compound 4: 2.0-fold (0.30 log units) above, within the range that was stated.
By their numbers in this assay, from the lowest: compounds 4, 1 and 2 (each within the scatter of the next). At a limit, above all of these: compound 3.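

Replacing pyrimidin-5-yl with 4-methylthiophen-2-yl on a saturated chain carbon bound to an amine nitrogen shows that the choice of aromatic ring at this place can shift the result in this assay, with an at least 8.0-fold lower number from compound 3 to compound 4 (0.90 log units; beyond the scatter). The value of compound 3 is a limit and not a number: the limit of > 100000 nM in this assay, at which 1 of the 4 values shown sits.

Changing the small group on the thiophene ring stays within the scatter, with a 2.0-fold lower number from compound 2 to compound 4 (0.30 log units; within the scatter) and a 2.0-fold lower number from compound 1 to compound 4 (0.30 log units; within the scatter). Still open, from the compounds shown here alone, is how a phenyl ring in that place, or an amine or a carboxylic acid on the thiophene ring, would read in this assay.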